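This account rests on a few compounds, and the source may have more. Where it says the series, first, only, none or still open, it means among the compounds named here.

Measured so far in a functional assay for inhibition, with Rattus norvegicus as the target; a lower number here means a stronger inhibitor, a higher number a weaker inhibitor:
- compound 1 `C[C@@H](/N=c1\c(O)c(O)\c1=N/Cc1ccc(C#N)cc1)C(C)(C)C`: 270 nM
- compound 2 `CC[C@H](C)/N=c1\c(O)c(O)\c1=N/Cc1ccc(C#N)cc1`: 2200 nM

Among the measured compounds shown here, of these two, compound 2 is the weaker inhibitor, at 2200 nM, and its only neighbour on the scale is compound 1. The next structure is compound 3 `CC(C)(C)/N=c1\c(O)c(O)\c1=N/Cc1ccc(C#N)cc1`, which has tert-butyl in place of sec-butyl on a double-bonded nitrogen. The two have the same atoms, joined differently.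

For the measured compounds named here, only one measured step bears on this change: an 8.1-fold higher number from compound 1 to compound 2 (0.91 log units; beyond the scatter). It is modest but beyond the scatter, and it involves sec-butyl in place of 1,2,2-trimethylpropyl on the same nitrogen. Going by the values given here, it is a single step, and no measurement yet covers tert-butyl. Here the heavy-atom count stays the same, so a smaller shift than that step is expected, tentatively towards a lower number, as the more branched group of compound 1 gave 270 nM. The expected step is a 2.2-fold lower number from compound 2 to compound 3 (0.34 log units; beyond the scatter). For compound 3 the estimate is 1000 nM, with an expected range of 300 nM to 3500 nM.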

Compound 3, half-maximal inhibitory concentration: 270 nM
The estimate for compound 3 lay 3.7-fold (0.57 log units) above the measured number, and the stated range ends above it.
By their numbers in this assay, from the lowest: compounds 1 and 3 (each within the scatter of the next); then compound 2.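

In this assay, rearranging the same carbons on the double-bonded nitrogen gives an 8.1-fold lower number from compound 2 to compound 3 (0.91 log units; beyond the scatter), so the change from sec-butyl to tert-butyl matters at this position even with the heavy-atom count unchanged, and the step is as large as the one seen earlier between two groups of different size, an 8.1-fold higher number from compound 1 to compound 2 (0.91 log units; beyond the scatter). The larger 1,2,2-trimethylpropyl group shows no change at the digits printed from compound 1 to compound 3 (within the scatter), so among these three compounds, size alone does not order the numbers, and tert-butyl matches 1,2,2-trimethylpropyl with fewer heavy atoms. No measurement at hand explains why these two butyl isomers differ.

Still open, going by these compounds, is whether a straight n-butyl, an isopropyl or a cyclohexyl on the double-bonded nitrogen would stay near compound 3 at 270 nM or move towards compound 2 at 2200 nM. Also open, on these data alone, are how the opposite stereoisomer of the sec-butyl compound would read and whether a tert-butyl compound would hold its number with a carboxylic acid in place of the nitrile.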